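This account rests on a few compounds, and the source may have more. Where it says the series, first, only, none or still open, it means among the compounds named here.

Measured compounds in a functional assay (aorta) with Rattus norvegicus as the target; a higher number here means a weaker inhibitor, a lower number a stronger inhibitor:
- compound 1, `CC1(C)Oc2ccc(C#N)cc2[C@@H](NC(=O)NCc2ccccc2)[C@@H]1O`: 5600 nM
- compound 2, `CC1(C)Oc2ccc(C#N)cc2[C@@H](/N=C(\NC#N)Nc2ccc(N)cc2)[C@@H]1O`: 3500 nM

Compound 2 is the cyanoguanidine with a 4-aminophenyl on the amine nitrogen; in this assay compound 2 gives 3500 nM. Compound 1, the benzylurea on the same core, gives 5600 nM in this assay. The two numbers lie within the scatter of each other, so nothing separates compound 1 from compound 2 on what is known.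

Compound 3, `CC1(C)Oc2ccc(C#N)cc2[C@@H](/N=C(\NC#N)Nc2ccc3c(c2)CCC3)[C@@H]1O`, is the next step and has not yet been measured in this assay. Relative to compound 2 the change is 2,3-dihydro-1H-inden-5-yl in place of 4-aminophenyl on an amine nitrogen. For the measured compounds named here, no pair of measured compounds shows this change, so its size and direction in this assay are unknown here; the donor and acceptor of the 4-aminophenyl leave and nothing of that kind enters.

The expectation is a step of about a 1.4-fold lower number from compound 2 to compound 3 (0.15 log units; within the scatter) in this assay, modest and not clearly beyond the scatter, in either direction. Compound 3 is therefore estimated at 2500 nM in this assay, with a range from 700 nM to 9000 nM.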

Compound 3, half-maximal inhibitory concentration: 41300 nM
For compound 3 the middle estimate is 17-fold (1.22 log units) below the measured one, and the stated range ends below it.
By their numbers in this assay, from the lowest: compounds 2 and 1 (each within the scatter of the next); then compound 3.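

In this assay, the group on this amine nitrogen of the cyanoguanidine turns out to matter: 2,3-dihydro-1H-inden-5-yl in place of 4-aminophenyl gives a 12-fold higher number from compound 2 to compound 3 (1.07 log units; beyond the scatter). For the compounds shown here, compound 1 and compound 2 differ in more than one place and gave no step at this position, so this pair is the only reading of it so far. The change removes a group with a hydrogen-bond donor and acceptor and brings in an all-carbon group with neither, plus a five-membered non-aromatic ring, but nothing measured here bears on why the number rises.

Going by these compounds alone, the single step cannot separate losing the amine from gaining the fused ring; a plain phenyl on the same nitrogen would split the two, and a hydroxyl or a carboxylic acid in the place of the amine would show whether the amine itself is needed or another group can stand in for it. From the compounds shown here alone, whether the same exchange has a similar effect on the benzylurea of compound 1 also remains open.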